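The source may hold more compounds than are shown below. What is called first, only, known or untested is meant among the compounds shown, and "the series" means these compounds.

In an in vitro ADME assay on microsomes from liver (Rattus norvegicus) for metabolic stability (on this read-out higher numbers stand for fast clearance and lower numbers for slow clearance), compound 1 `Cc1ccc(Cn2c(=O)[nH]c3c(N)nc(C(F)(F)F)cc32)cn1` gives < 8.5 mL.min-1.g-1. This is a limit of the assay and not a number. Compound 2 `Cc1ccc(Cn2c(=O)[nH]c3c(N)nc(C(F)(F)F)cc32)nn1` gives < 11 mL.min-1.g-1, which is also a limit. For the measured compounds named here, the only measured step is a step that the two limits leave unreadable from compound 1 to compound 2, with 6-methylpyridazin-3-yl in place of 6-methylpyridin-3-yl, and it offers no size to carry forward. Compound 3 `Nc1nc(C(F)(F)F)cc2c1[nH]c(=O)n2Cc1ccc(C(F)(F)F)nc1` has not yet been measured. Its difference from compound 1 is trifluoromethyl in place of methyl on an aromatic carbon of a six-membered aromatic ring with 1 nitrogen, next to the ring nitrogen. The measured step leaves the methyl in place, so it bears on this change only loosely. The expectation therefore starts from compound 1 and its limit of < 8.5 mL.min-1.g-1. With no readable step to guide it, no step beyond the usual scatter is expected, and no firm direction can be given. The estimated step is a step that the limit leaves unreadable from compound 1 to compound 3. In this assay, compound 3 is expected to give 8 mL.min-1.g-1, with an estimated range of 4 mL.min-1.g-1 to 18 mL.min-1.g-1.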

Compound 3, intrinsic clearance in microsomes: < 8.5 mL.min-1.g-1
Compound 3 gave a limit, no number; the forecaster's own chance of this, stated with the estimate: 60%; the middle value is on the limit's open side.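

Compound 1 and compound 3 both give limits and not numbers in this assay, so the step between them, trifluoromethyl in place of methyl, cannot be read. The compounds shown leave open what clearance compound 1, compound 2 and compound 3 actually have, and whether either change shifts it at all.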